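Swapping the aryl on the triazole of compound 3

The source may report more compounds than this note shows. Statements on the series, on what has been measured and on what is new or still open speak of the compounds shown alone.

Compound 1 `N#CC1=C(N)Oc2c(c3nc4ccccc4nc3c3ccccc23)C12C(=O)N(Cc1cnnn1-c1ccc(F)cc1)c1ccccc12` reaches only the limit > 50000 nM in an ADME assay on L02 cells (Homo sapiens) for antiproliferative activity, read by MTT assay, with a stated time of 48 h; on this read-out lower numbers stand for stronger inhibition and higher numbers for weaker inhibition.
Compound 2 `Cc1ccc(-n2nncc2CN2C(=O)C3(C(C#N)=C(N)Oc4c3c3nc5ccccc5nc3c3ccccc43)c3ccccc32)cc1C` likewise reaches only the limit > 50000 nM in this assay.
Compound 3 `CCc1ccccc1-n1nncc1CN1C(=O)C2(C(C#N)=C(N)Oc3c(N)cc4nc5ccccc5nc4c32)c2ccccc21` gives 22900 nM in this assay.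

Among the measured compounds shown here, compound 3 thus holds the only real number among the three; the other two values are limits, sitting at the limit of > 50000 nM in this assay, at which 2 of the 3 values shown sit. The move to compound 4 `N#CC1=C(N)Oc2c(N)cc3nc4ccccc4nc3c2C12C(=O)N(Cc1cnnn1-c1ccc(Cl)cc1Cl)c1ccccc12` is 2,4-dichlorophenyl in place of 2-ethylphenyl on an aromatic nitrogen. For the measured compounds named here, the single step measured between compounds that differ in one place, a step that the two limits leave unreadable from compound 1 to compound 2, exchanges one aryl for another on the same aromatic nitrogen, but both ends are limits, so its size cannot be read. Nothing measured therefore tells how large a step to expect in this assay from this kind of exchange, in either direction. With two of three values at the limit, compound 4 is expected to stay weak, and the step of a 1.3-fold higher number from compound 3 to compound 4 (0.12 log units; within the scatter) is estimated to lie within the usual scatter. Compound 4 is estimated at 30000 nM, between 12000 nM and 60000 nM, with a real chance that only a limit is reported.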

Compound 4, half-maximal inhibitory concentration: > 50000 nM
Compound 4: only a limit was reported; the forecaster's own chance of this, stated with the estimate: 40%; middle value at least 1.6-fold (0.22 log units) away from the limit.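

Unlike the step between compound 1 and compound 2, which the two limits leave unreadable, this exchange of one aryl group for another on the same aromatic nitrogen has a readable lower bound in this assay: an at least 2.1-fold higher number from compound 3 to compound 4 (0.33 log units; beyond the scatter). The two groups match in heavy-atom count and each holds one six-membered aromatic ring of carbon only, so the read-out at this position responds to which atoms the aryl group carries, not only to their number. Compound 4 gives only a limit, and it joins the other compounds there: the limit of > 50000 nM in this assay, at which 3 of the 4 values shown sit.

From the compounds shown here alone, how much of the step comes from adding the two chlorines and how much from losing the ethyl remains open. A plain phenyl group or a methoxyphenyl group on this nitrogen would help separate the two, and could show whether any aryl group here gives a lower number than compound 3.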